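The source may report more compounds than this note shows. Statements on the series, on what has been measured and on what is new or still open speak of the compounds shown alone.

Measured so far, in a functional assay on cells (Cancer cell lines, Homo sapiens) for cytotoxicity, read by sulforhodamine B assay, with a stated time of 48 h; a lower number here means a stronger inhibitor of growth, a higher number a weaker inhibitor of growth:

compound 1, `COc1ccc(C2CC(c3ccc4ccccc4c3)=NN2C2=NC(=O)/C(=C3\C(=O)Nc4ccccc43)S2)cc1`: 32800 nM
compound 2, `O=C1N=C(N2N=C(c3ccccc3)CC2c2ccc(Cl)cc2)S/C1=C1/C(=O)Nc2ccccc21`: 910 nM
compound 3, `COc1ccc(C2=NN(C3=NC(=O)/C(=C4\C(=O)Nc5ccccc54)S3)C(c3ccc(Cl)cc3)C2)cc1`: 100000 nM

Compound 3 gives the highest of the three numbers in this assay. Among the compounds with values here, its nearest neighbour is compound 1, and the gap to compound 2 is wide, as the single step of a 110-fold higher number from compound 2 to compound 3 (2.04 log units; beyond the scatter) shows.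

Compound 4, `O=C1N=C(N2N=C(c3ccc4ccccc4c3)CC2c2ccc(Cl)cc2)S/C1=C1/C(=O)Nc2ccccc21`, is not yet measured. It differs from compound 3 in one place: naphthalen-2-yl in place of 4-methoxyphenyl on a carbon with a double bond to nitrogen. Seen from the other side, compound 4 is compound 2 with naphthalen-2-yl in place of phenyl at that carbon.

Within the data shown here, only one measured step touches this position, a 110-fold higher number from compound 2 to compound 3 (2.04 log units; beyond the scatter), and it is large. It tells that the 4-methoxyphenyl group goes with a much weaker result than a bare phenyl at that carbon; it does not tell how naphthalen-2-yl behaves there. Compound 1 carries naphthalen-2-yl at the same carbon but a 4-methoxyphenyl instead of 4-chlorophenyl on the other ring atom, so its value bears only loosely on compound 4.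

Compound 4 is therefore expected to sit well below compound 3, with the step of a 20-fold lower number from compound 3 to compound 4 (1.30 log units; beyond the scatter) estimated to be large, though the range is wide. The estimate for compound 4 in this assay is 5000 nM, between 800 nM and 40000 nM.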

Compound 4, concentration for total growth inhibition: 38300 nM
Beside the measured number, compound 4's estimate is 7.7-fold (0.88 log units) below it; the range from low to high includes it.
By their numbers in this assay, from the lowest: compound 2; then compounds 1 and 4 (each within the scatter of the next); then compound 3.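

In this assay, a 42-fold higher number from compound 2 to compound 4 (1.62 log units; beyond the scatter) now stands alongside a 110-fold higher number from compound 2 to compound 3 (2.04 log units; beyond the scatter), so the move away from a weaker result is not peculiar to 4-methoxyphenyl: of the three groups seen on the carbon with a double bond to nitrogen, only phenyl gives a low number. The two replacements of phenyl also differ from each other, though far less than either differs from phenyl, with a 2.6-fold lower number from compound 3 to compound 4 (0.42 log units; beyond the scatter), so naphthalen-2-yl recovers only a small part of what 4-methoxyphenyl gives up. Within the data shown here, the result also gives the first reading at the other substituted ring atom: with naphthalen-2-yl held in place, a 1.2-fold higher number from compound 1 to compound 4 (0.07 log units; within the scatter) lies within the scatter, so 4-chlorophenyl and 4-methoxyphenyl cannot be told apart there.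

No measurement offered here explains why phenyl stands apart from the other two groups at this carbon. Going by these compounds, it remains open how a methyl group, a 4-aminophenyl group or a pyridine ring would behave at this carbon, and whether 4-chlorophenyl and 4-methoxyphenyl would still read alike at the other ring atom with phenyl in place of naphthalen-2-yl.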